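Swapping a Chain for a Ring on an Endothelin Antagonist

The source may hold more compounds than are shown below. What is called first, only, known or untested is meant among the compounds shown, and "the series" means these compounds.

Three measured compounds share a sulfonamide core. In an assay on VSM-A10 cells for antagonist activity at Endothelin-1 receptor (Rattus norvegicus) (on this read-out lower numbers stand for stronger inhibition and higher numbers for weaker inhibition), compound 1 `CCCCCNc1cccc2c(S(=O)(=O)Nc3onc(C)c3C)cccc12` gives 80 nM, the lowest of the three numbers. Compound 3 `Cc1noc(NS(=O)(=O)c2ccc(N/C(S)=N/c3ccccc3)cc2)c1C` gives 4100 nM in this assay, and compound 2 `Cc1noc(NS(=O)(=O)c2cccc3c(N(C)C)cccc23)c1Cc1ccccc1` gives 50000 nM, both separated from compound 1 by gaps well beyond the usual scatter, so compound 1 is the strongest inhibitor of the three.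

Compound 4 `Cc1noc(NS(=O)(=O)c2cccc3c(N4CCCC4=O)cccc23)c1C` has not yet been measured. It differs from compound 1 in one place: 2-oxopyrrolidin-1-yl in place of pentylamino on an aromatic carbon. The pentylamino group is an open chain carrying a hydrogen-bond donor, while the 2-oxopyrrolidin-1-yl group is a closed five-membered ring with a carbonyl and no hydrogen-bond donor. Within the data shown here, no measured pair shows this exact change, so its effect is uncertain. The expectation is a moderate loss of potency, a step of a 5.0-fold higher number from compound 1 to compound 4 (0.70 log units; beyond the scatter). Compound 4 is expected to give about 400 nM in this assay, most likely between 100 nM and 2000 nM.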

Compound 4, half-maximal inhibitory concentration: 130 nM
The estimate for compound 4 lay 3.1-fold (0.49 log units) above the measured number; the measured number falls inside the stated range.
By their numbers in this assay, from the lowest: compounds 1 and 4 (each within the scatter of the next); then compound 3; then compound 2.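

In this assay, 2-oxopyrrolidin-1-yl in place of pentylamino gives a 1.6-fold higher number from compound 1 to compound 4 (0.21 log units; within the scatter) and so leaves the number essentially unchanged. At this aromatic carbon, then, the open chain and its hydrogen-bond donor are not needed to keep a number of this size, since the closed ring carries no such donor and the two compounds cannot be told apart. No measurement on hand explains why these two different groups perform alike.

Because the ring and the carbonyl arrive together, this single change cannot show what each contributes alone; a plain pyrrolidin-1-yl ring, without the carbonyl, would separate the two. As far as these compounds go, how far this tolerance extends also remains open, for example to a carboxylic acid or a longer chain on the same carbon.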